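From 2,4-dimethylphenyl to 2-methoxyphenyl in compound 4

The source may report more compounds than this note shows. Statements on the series, on what has been measured and on what is new or still open speak of the compounds shown alone.

Three compounds have been measured in an assay on membranes from liver for displacement of a labelled ligand from Sigma non-opioid intracellular receptor 1 (Rattus norvegicus), read by scintillation counting; a higher number here means a weaker inhibitor, a lower number a stronger inhibitor:
compound 1 `Cc1ccc(CN(C)CCCCn2c(=O)oc3ccccc32)c(C)c1`: 239 nM
compound 2 `CN(CCCn1c(=O)oc2ccccc21)Cc1ccccc1`: 223 nM
compound 3 `Cc1cccc(CN(C)CCCn2c(=O)oc3ccccc32)c1`: 1840 nM

Among these numbers compound 1 stands second highest. Its nearest neighbour is compound 2, whose value lies within the scatter of that of compound 1, so the two cannot be told apart; the furthest is compound 3, which sits well beyond the scatter above compound 1. Among the compounds with values here, the only single-point step among the measured compounds is an 8.3-fold higher number from compound 2 to compound 3 (0.92 log units; beyond the scatter), a methyl on an aromatic carbon of the shorter-chain compound.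

The unmeasured compound 4 `COc1ccccc1CN(C)CCCCn1c(=O)oc2ccccc21` arises from compound 1 by the change (2-methoxyphenyl in place of 2,4-dimethylphenyl on a saturated chain carbon bound to an amine nitrogen). The measured step bears on this only loosely: it concerns a methyl added to an unsubstituted ring, whereas here both methyls leave and a methoxy enters. Compound 1, with its two methyls, and compound 2, with none, give values within the scatter of each other, which gives no direction for removing them. In this assay compound 4 is therefore expected to lie close to compound 1, with the step of a 1.3-fold higher number from compound 1 to compound 4 (0.10 log units; within the scatter) not beyond the scatter. The estimate for compound 4 is 300 nM, within 100 nM to 1000 nM.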

Compound 4, inhibition constant: 594 nM
Compound 4: middle estimate off by 2.0-fold (0.30 log units), on the low side, within the range that was stated.
By their numbers in this assay, from the lowest: compounds 2 and 1 (each within the scatter of the next); then compound 4; then compound 3.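

In this assay, the exchange of 2,4-dimethylphenyl for 2-methoxyphenyl on a saturated chain carbon bound to an amine nitrogen gives a 2.5-fold higher number from compound 1 to compound 4 (0.40 log units; beyond the scatter), so compound 4 is the weaker inhibitor of this pair. The earlier single-point step concerned only a methyl added to the unsubstituted ring of compound 2, whereas this result shows that the substituents on the ring can also move the number in the longer-chain compound. The size of the group does not have to change for this to happen: both groups have 8 heavy atoms and one six-membered aromatic ring of carbon only, while the entering group brings an oxygen and 1 hydrogen-bond acceptor. Nothing available here gives a measured reason for the difference between these two groups.

The compounds shown leave open whether the step comes from the loss of the two methyls or from the arrival of the methoxy, since this single exchange does both at once. They also leave open how a chlorine or an ethoxy group on this ring would read in this assay, and how either would behave on a longer chain.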